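The compounds below may be only part of what the source reports. "The series", "measured", "known", "first", "only" and "open" are said of these compounds alone.

Working notes on a small set tested in a functional assay, with a stated time of 30 min; a lower number here means a stronger inhibitor, a higher number a weaker inhibitor. Compound 1 `COC(=O)c1c(C(=O)c2c(O)cc(C)cc2OC)c(OC)cc(O)c1[S+](C)[O-]` carries a small sulfur-bearing substituent on the shared core; in this assay compound 1 gives > 100000 nM, which is a limit of the measurement and not a number. Compound 2 `COC(=O)c1c2c(cc(OC)c1C(=O)c1c(O)cc(C)cc1OC)O[C@@H](OC)CS2` is a variant of the same core with an additional fused ring; in this assay compound 2 gives > 100000 nM, again a limit rather than a number. Compound 3 `COc1c(O)c(O)c(C)c2scnc12` is a smaller, different structure; in this assay compound 3 gives 3450 nM, the only numerical result so far. Within the data shown here, no two measured compounds differ in a single place, so no measured step exists, and the results of compound 1 and compound 2 show only that both sit at the limit of > 100000 nM in this assay, at which 2 of the 3 values shown sit.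

Compound 4 `COC(=O)c1cc(O)cc(OC)c1C(=O)c1c(O)cc(C)cc1OC` follows from compound 1 by one change: a hydrogen atom in place of a group of 3 heavy atoms (1 carbon, 1 oxygen, 1 sulfur; no ring), on an aromatic carbon. Since compound 1 stands at a limit, the size of the move to compound 4 cannot be anchored on data. Among the measured compounds shown here, the single number, from compound 3 at 3450 nM, belongs to another scaffold. Compound 4 is expected to give roughly 40000 nM in this assay, within a range of 5000 nM to 150000 nM, with a limit nearly as likely as a number. This corresponds to an expected step of an at least 2.5-fold lower number from compound 1 to compound 4 (0.39 log units; beyond the scatter), a modest gain in inhibition at most.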

Compound 4, half-maximal inhibitory concentration: > 100000 nM
Compound 4 was reported as a limit; the forecaster's own chance of this, stated with the estimate: 45%; at least 2.5-fold (0.39 log units) between middle value and limit.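

No step can be read between compound 1 and compound 4, since both results are limits of the measurement and not numbers: the limit of > 100000 nM in this assay, at which 3 of the 4 values shown sit. The compounds shown leave open how far a hydrogen atom in place of the group of 3 heavy atoms moves the result in this assay, and whether the shared core can give a numerical result there.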